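Coumarin-isoxazole cytotoxicity: moving the chlorine on the phenyl ring

The source may hold more compounds than are shown below. What is called first, only, known or untested is meant among the compounds shown, and "the series" means these compounds.

The series comprises four compounds built on a shared core. In a functional assay on COLO 205 cells (Homo sapiens) for cytotoxicity, read by MTT assay, with a stated time of 48 h (on this read-out higher numbers stand for weaker inhibition and lower numbers for stronger inhibition), compound 1 `O=c1ccc2cc(OCc3cc(-c4ccccc4)no3)ccc2o1` gives "not determined" (no result reported). In this assay compound 2 `COc1cccc(-c2cc(COc3ccc4oc(=O)ccc4c3)on2)c1` gives "not determined" (no result reported). Among the compounds with values here, compound 3 `O=c1ccc2cc(OCc3cc(-c4cccc(Cl)c4)no3)ccc2o1` is the only member with a number: in this assay compound 3 gives 32500 nM, so it stands alone and offers no comparison within the set. Compound 4 `O=c1ccc2cc(OCc3cc(-c4ccc(Cl)cc4)no3)ccc2o1` has not yet been measured. Its structure differs from that of compound 3 only by 4-chlorophenyl in place of 3-chlorophenyl on an aromatic carbon. Within the data shown here, with no step between two measured compounds available, the expected change is none beyond the scatter, so the step of a 1.1-fold lower number from compound 3 to compound 4 (0.03 log units; within the scatter) is estimated as essentially flat. Accordingly compound 4 is expected to give about 30000 nM in this assay, within a range of 10000 nM to 90000 nM.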

Compound 4, half-maximal inhibitory concentration: 44500 nM
Beside the measured number, compound 4's estimate is 1.5-fold (0.17 log units) below it, and the stated range covers the measured number.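

Moving the chlorine, with 4-chlorophenyl in place of 3-chlorophenyl, gives a 1.4-fold higher number from compound 3 to compound 4 (0.14 log units; within the scatter) in this assay and so stays within the scatter. Within the data shown here, at this position, on an aromatic carbon of the five-membered aromatic ring, the read-out therefore does not separate the two chlorophenyl compounds, which the single earlier number could not show. Going by these compounds, whether an amine or a carboxylic acid on the phenyl ring would change the number remains open, and the steps to compound 1 and compound 2 cannot be read. Nothing among the data shown accounts for this result.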